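Oxazole to Imidazole: Expecting Little Change in Paw Edema

The source may report more compounds than this note shows. Statements on the series, on what has been measured and on what is new or still open speak of the compounds shown alone.

Compound 1, `CC(=O)Oc1ccc(-n2cccc2)cc1C(=O)O`, gives 42 mg/kg in a functional assay on the whole organism for inhibition, with Rattus norvegicus as the target, read by paw edema; a higher number here means that more compound is needed for the effect, a lower number that less compound is needed.
Compound 2, `O=C(O)c1cc(-c2cccs2)ccc1O`, gives 60 mg/kg in this assay.
Compound 3, `O=C(O)c1cc(-c2ncco2)ccc1O`, gives 100 mg/kg in this assay.

Among the three measured compounds, compound 3 carries the highest number, so it needs the most compound for the effect. Its nearest neighbour is compound 2, whose value lies within the usual scatter of compound 3, so no order between those two can be claimed. Compound 1 lies furthest away, beyond the scatter, and so clearly needs less compound than compound 3.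

The unmeasured compound 4, `O=C(O)c1cc(-c2ncc[nH]2)ccc1O`, differs from compound 3 in a single place: 1H-imidazol-2-yl in place of 1,3-oxazol-2-yl on an aromatic carbon. For the measured compounds named here, only one measured step bears on this kind of change, the swap of one five-membered aromatic ring with two hetero atoms for another on the same carbon of the shared core: a 1.7-fold higher number from compound 2 to compound 3 (0.22 log units; within the scatter). That step stayed within the scatter. On that basis no step beyond the scatter is expected in this assay for the present swap either.

Compound 4 is therefore estimated to give about 100 mg/kg, with a range from 50 mg/kg to 200 mg/kg. The expected step is no change at the digits printed from compound 3 to compound 4 (within the scatter), essentially flat.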

Compound 4, dose for half-maximal effect: 200 mg/kg
Compound 4: middle estimate off by 2.0-fold (0.30 log units), on the low side, within the range that was stated.
By their numbers in this assay, from the lowest: compounds 1, 2, 3 and 4 (each within the scatter of the next, the first and the last beyond it).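

Read alone, the change at this carbon, para to a hydroxy group and meta to a carboxy group, stays inside the noise: in this assay, replacing 1,3-oxazol-2-yl with 1H-imidazol-2-yl gives a 2.0-fold higher number from compound 3 to compound 4 (0.30 log units; within the scatter), so compound 3 and compound 4 cannot be put in order, even though the entering ring has 1 hydrogen-bond donor and the leaving ring has 0. For the compounds shown here, the wider swap at the same carbon, 1H-imidazol-2-yl in place of thiophen-2-yl, gives a 3.3-fold higher number from compound 2 to compound 4 (0.52 log units; beyond the scatter), and this is the first ring exchange here that clearly exceeds the scatter, showing that the choice of five-membered ring can matter in this assay, though only modestly so far. The data offer no measurement that could explain this difference.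

Going by these compounds, it remains open whether the hydrogen on the ring nitrogen of 1H-imidazol-2-yl plays any part, which a 1-methyl-1H-imidazol-2-yl group at the same carbon could help to test. On these data alone, it is also open how groups other than five-membered rings would read at this carbon, such as a phenyl ring, an amine or a longer alkyl chain.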